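A few compounds are considered here, and "the series" means these few. Any claim that something is new, unique, unknown or untested is made for them only; others in the source may bear on it.

Measured so far in an ADME assay on stomach for pharmacokinetics, in simulated gastric fluid; a lower number here means that the compound disappears faster, a higher number that the compound lasts longer:
compound 1 `CCOc1cc(NC(=O)C2(NC(=O)c3ccc4c(C5CCCC5)c(-c5ncc(Cl)cn5)n(C)c4c3)CCC2)ccc1/C=C/C(=O)N[C@@H](CCC(=O)O)C(N)=O` gives 0.533 h
compound 2 `CCCCCCOC(=O)/C=C/c1ccc(NC(=O)C2(NC(=O)c3ccc4c(C5CCCC5)c(-c5ncc(Cl)cn5)n(C)c4c3)CCC2)cc1OCC` gives 0.883 h
compound 3 `CCOc1cc(NC(=O)C2(NC(=O)c3ccc4c(C5CCCC5)c(-c5ncc(Cl)cn5)n(C)c4c3)CCC2)ccc1/C=C/C(=O)OCC(Cl)(Cl)Cl` gives 1.75 h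

Compound 3 holds the highest of the three numbers. The step of a 2.0-fold higher number from compound 2 to compound 3 (0.30 log units; within the scatter) lies within the scatter; the step of a 3.3-fold higher number from compound 1 to compound 3 (0.52 log units; beyond the scatter) lies beyond it. Compound 4 `CCOc1cc(NC(=O)C2(NC(=O)c3ccc4c(C5CCCC5)c(-c5ncc(Cl)cn5)n(C)c4c3)CCC2)ccc1/C=C/C(=O)OCC(N)=O` differs from compound 3 by carbamoyl in place of trichloromethyl on a saturated chain carbon bound to an oxygen next to a carbonyl group. Among the compounds with values here, two steps bear on this position: a 2.0-fold higher number from compound 2 to compound 3 (0.30 log units; within the scatter) swapped one group on the same carbon and stayed within the scatter, while a 3.3-fold higher number from compound 1 to compound 3 (0.52 log units; beyond the scatter) removed a chain carrying a carbamoyl and was modest. Since compound 4 brings a carbamoyl back, a modest downward step is expected, a 1.9-fold lower number from compound 3 to compound 4 (0.29 log units; within the scatter). Compound 4 is therefore estimated at 0.9 h, expected between 0.4 h and 2 h.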

Compound 4, half-life: 0.6 h
Beside the measured number, compound 4's estimate is 1.5-fold (0.18 log units) above it, within the range that was stated.
By their numbers in this assay, from the lowest: compounds 1, 4, 2 and 3 (each within the scatter of the next, the first and the last beyond it).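

In this assay, within the data shown here, carbamoyl in place of trichloromethyl on this saturated chain carbon gives a 2.9-fold lower number from compound 3 to compound 4 (0.46 log units; beyond the scatter), the first change at this carbon to pass the scatter. The other two steps stay within it, a 1.5-fold lower number from compound 2 to compound 4 (0.17 log units; within the scatter) and a 1.1-fold higher number from compound 1 to compound 4 (0.05 log units; within the scatter), so compound 2, with its pentyl group, separates from neither compound 3 nor compound 4. Nothing at hand accounts for the step at this carbon. From the compounds shown here alone, whether trifluoromethyl or an amine on this carbon would read like trichloromethyl or like carbamoyl remains open.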